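This account rests on a few compounds, and the source may have more. Where it says the series, first, only, none or still open, it means among the compounds named here.

Measured compounds in a functional assay on MGC-803 cells (Homo sapiens) for antiproliferative activity, read by MTT assay, with a stated time of 72 h; on this read-out lower numbers stand for stronger inhibition and higher numbers for weaker inhibition:
- compound 1 `CCCSc1nc(N/N=C(\C)c2ccccc2O)c2nnn(Cc3ccc(F)cc3)c2n1`, giving 11000 nM
- compound 2 `CCCSc1nc(N/N=C/c2ccc(Br)cc2)c2nnn(Cc3ccccc3)c2n1`, giving 34900 nM

Of the two compounds measured in this assay, compound 1 gives the lower number, and its gap to compound 2 lies beyond the usual scatter of repeated measurements. Compound 3 `CCCSc1nc(N/N=C(\C)c2ccccc2O)c2nnn(Cc3ccco3)c2n1` has not yet been measured. It keeps the core of compound 1 and differs in one place: furan-2-yl in place of 4-fluorophenyl on a saturated chain carbon bound to an aromatic nitrogen. For the measured compounds named here, no pair of measured compounds shows what this kind of exchange does in this assay, so the expectation can rest only on compound 1 itself. A step of modest size from compound 1 to compound 3 is expected, in either direction, and most likely not beyond the scatter: a 1.4-fold higher number from compound 1 to compound 3 (0.13 log units; within the scatter). Compound 3 is therefore estimated at 15000 nM, with a range from 5000 nM to 45000 nM.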

Compound 3, half-maximal inhibitory concentration: 4760 nM
Compound 3: the middle estimate sits 3.2-fold (0.50 log units) above what was measured; the measured number lies below the stated range.
By their numbers in this assay, from the lowest: compound 3; then compound 1; then compound 2.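

In this assay the group on a saturated chain carbon bound to an aromatic nitrogen can be changed with a clear effect: furan-2-yl in place of 4-fluorophenyl gives a 2.3-fold lower number from compound 1 to compound 3 (0.36 log units; beyond the scatter) and so stronger inhibition. For the compounds shown here, this is the first step that isolates one position, and it shows that a five-membered aromatic ring with one oxygen, at 5 heavy atoms against 7, is tolerated there and even improves the number. Nothing available here accounts for the gain.

On these data alone, whether the lower number follows from the ring oxygen, the smaller ring or the loss of fluorine stays open, and a thiophen-2-yl group, with sulfur in the place of that oxygen, would help to separate these. As far as these compounds go, whether the same exchange holds with other groups elsewhere on the shared core also remains unknown.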